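Swapping the aryl substituent on the shared core of compound 3

A few compounds are considered here, and "the series" means these few. Any claim that something is new, unique, unknown or untested is made for them only; others in the source may bear on it.

In a functional assay on MV4-11 cells (Homo sapiens) for antiproliferative activity, read by CCK-8 assay, with a stated time of 72 h (on this read-out higher numbers stand for weaker inhibition and lower numbers for stronger inhibition), compound 3 `COc1ccc(-c2cn(C)c(=O)c3[nH]c(C(=O)NCc4ccc(C(=O)Nc5ccccc5N)cc4)cc23)cc1` gives 320 nM, the highest of the three numbers. Compound 1 `CC(C)Oc1ccccc1-c1cn(C)c(=O)c2[nH]c(C(=O)NCc3ccc(C(=O)Nc4ccccc4N)cc3)cc12` gives 130 nM and compound 2 `Cn1cc(-c2cc(C(C)(C)O)ccc2Oc2ccccc2)c2cc(C(=O)NCc3ccc(C(=O)Nc4ccccc4N)cc3)[nH]c2c1=O` gives 100 nM. Going by the values given here, the only measured step that bears on the new compound is a 2.5-fold higher number from compound 1 to compound 3 (0.39 log units; beyond the scatter). Compound 4 `COc1ccc(C(C)(C)O)cc1-c1cn(C)c(=O)c2[nH]c(C(=O)NCc3ccc(C(=O)Nc4ccccc4N)cc3)cc12` differs from compound 3 by 5-(1-hydroxy-1-methylethyl)-2-methoxyphenyl in place of 4-methoxyphenyl on an aromatic carbon. Since a 2-alkoxy pattern on this aryl ring went with a lower number in compound 1, and compound 2, which also carries a 1-hydroxy-1-methylethyl group, shows a lower number than compound 3, a return toward lower numbers is expected: a 2.7-fold lower number from compound 3 to compound 4 (0.43 log units; beyond the scatter). Compound 4 is therefore estimated at 120 nM, within 50 nM to 300 nM.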

Compound 4, half-maximal inhibitory concentration: 420 nM
Compound 4: middle estimate off by 3.5-fold (0.54 log units), on the low side, outside the stated range (above it).
By their numbers in this assay, from the lowest: compounds 2 and 1 (each within the scatter of the next); then compounds 3 and 4 (each within the scatter of the next).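

In this assay there is a 1.3-fold higher number from compound 3 to compound 4 (0.12 log units; within the scatter), so this larger aryl group, with its 1-hydroxy-1-methylethyl group and its 2-methoxy pattern, leaves the number where the 4-methoxyphenyl group had it. The oxygen substituent now matters, with a 4.2-fold higher number from compound 2 to compound 4 (0.62 log units; beyond the scatter) when methyl takes the place of phenyl, and the aryl group as a whole gives a 3.2-fold higher number from compound 1 to compound 4 (0.51 log units; beyond the scatter) when it takes the place of 2-isopropoxyphenyl. No measured evidence accounts for these steps. Still open, from the compounds shown here alone, is how an ethyl group or a longer chain on that oxygen would read, and whether an amine or a carboxylic acid in place of the 1-hydroxy-1-methylethyl group would shift the number.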